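From methyl to trifluoromethyl on compound 2

A few compounds are considered here, and "the series" means these few. Any claim that something is new, unique, unknown or untested is made for them only; others in the source may bear on it.

Measured so far:
- Compound 1 `Cc1ccc2nc(-c3ccccc3N(C)C)[nH]c(=O)c2c1` gives 26700 nM
- Compound 2 `Cc1cccc(-c2nc3ccc(C)cc3c(=O)[nH]2)c1` gives > 50000 nM

In a functional assay on T47D cells (Homo sapiens) for cytotoxicity, read by MTT assay, with a stated time of 2 days (a lower number here means a stronger inhibitor, a higher number a weaker inhibitor), compound 2 gives > 50000 nM and this is a limit of the assay, not a number. Compound 1 is the only one of the two with a measured number. Compound 3 `Cc1ccc2nc(-c3cccc(C(F)(F)F)c3)[nH]c(=O)c2c1` has trifluoromethyl in place of methyl on an aromatic carbon, and the rest of compound 2 stays the same. Going by the values given here, no measured pair of compounds shows what this change does. In this assay the most likely outcome is therefore no shift beyond the usual scatter, with a slight lean towards a stronger inhibitor. The expected step (an at least 1.2-fold lower number from compound 2 to compound 3 (0.09 log units; that floor lies within the scatter)) is a rough estimate and starts from a limit. For compound 3 the estimate is 40000 nM with an expected range of 15000 nM to 90000 nM and the assay may again report only a limit.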

Compound 3, half-maximal inhibitory concentration: > 50000 nM
Compound 3: a limit, no number; the forecaster's own chance of this, stated with the estimate: 45%; at least 1.2-fold (0.09 log units) between middle value and limit.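

In this assay compound 2 and compound 3 both stop at a limit of the assay, so no step can be read between them: the limit of > 50000 nM in this assay, at which 2 of the 3 values shown sit.
What trifluoromethyl in place of methyl on an aromatic carbon does to the number stays open with the compounds shown.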